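Benzoyl for propanoyl on the shared core

The source may report more compounds than this note shows. Statements on the series, on what has been measured and on what is new or still open speak of the compounds shown alone.

Compound 1 `CCC(=O)Oc1c(C(C)C)cc2c3c1OC(=O)[C@@]31CCCC(C)(C)[C@@H]1CC2` is the reference point for this step. Going by the values given here, in an ADME assay on MRC5 cells (Homo sapiens) for cytotoxicity, read by neutral red uptake, with a stated time of 24 h (on this read-out lower numbers stand for stronger inhibition and higher numbers for weaker inhibition), compound 1 gives 125000 nM, the only true number available for the series. Compound 2 `CCCCCCCCCCCCCCCC(=O)Oc1c(C(C)C)cc2c3c1OC(=O)[C@@]31CCCC(C)(C)[C@@H]1CC2` reports only a limit of the assay, > 1000000 nM. Among the compounds with values here, no measured step connects the two compounds, so the series offers no direct calibration for a change at this site.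

Compound 3 `CC(C)c1cc2c3c(c1OC(=O)c1ccccc1)OC(=O)[C@@]31CCCC(C)(C)[C@@H]1CC2` keeps the core of compound 1 and alters one group, with phenyl in place of ethyl on a carbonyl carbon, so that propanoyloxy becomes benzoyloxy: phenyl in place of ethyl on a carbonyl carbon. Any shift in this assay is expected to be small, with no more than a slight lean towards weaker inhibition. That lean is tentative and is expected because compound 2 gives the limit > 1000000 nM. The estimated 1.4-fold higher number from compound 1 to compound 3 (0.13 log units; within the scatter) lies within the usual scatter, so no clear change is expected. For compound 3 the estimated value is 170000 nM, with an expected range from 60000 nM to 500000 nM.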

Compound 3, half-maximal inhibitory concentration: 512000 nM
Compound 3: middle estimate off by 3.0-fold (0.48 log units), on the low side; measured number above the stated range.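

Phenyl in place of ethyl on a carbonyl carbon gives the series its first readable step: in this assay, the change produces a 4.1-fold higher number from compound 1 to compound 3 (0.61 log units; beyond the scatter). This shows that the read-out responds to a change at this site, and that the move from propanoyloxy to benzoyloxy goes towards weaker inhibition, not stronger. Compound 2 provides only a limit, so it gives no second step to set beside this one: the limit of > 1000000 nM in this assay, at which 1 of the 3 values shown sits.

A single step cannot tell whether the shift follows the aromatic ring itself or simply the larger group on the carbonyl carbon, and a saturated cyclohexyl at the same place would separate those two readings. From the compounds shown here alone, it also remains open how a phenyl carrying an amine or a carboxylic acid would read in this assay, or whether a butyl chain, lying in size between ethyl and the long chain of compound 2, would give a true number rather than a limit.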